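The source may hold more compounds than are shown below. What is called first, only, known or untested is meant among the compounds shown, and "the series" means these compounds.

Series notes. Two members of this series have been measured in a functional assay on TK-10 cells (Homo sapiens) for antiproliferative activity, read by sulforhodamine B assay, with a stated time of 48 h; a higher number here means a weaker inhibitor of growth, a lower number a stronger inhibitor of growth. Compound 1 `Cc1nc(SCC(=O)Nc2nc(-c3ccc(Cl)cc3)cs2)n(Nc2ccccc2)c1C` gives 3650 nM in this assay. Compound 2 `Cc1ccc(Nn2c(SCC(=O)Nc3nc(-c4ccccc4)cs3)nc(C)c2C)cc1` differs from compound 1 in two places at once, and in this assay compound 2 gives 18900 nM. Compound 1 thus stands at the lower of the two numbers, and the gap to compound 2 lies beyond the scatter of the method; because the two structures differ in more than one place, the gap cannot be assigned to either change on its own.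

Compound 3 `COc1ccc(Nn2c(SCC(=O)Nc3nc(-c4ccc(Cl)cc4)cs3)nc(C)c2C)cc1` has not yet been measured. It differs from compound 1 by methoxy in place of hydrogen on an aromatic carbon. Within the data shown here, no measured pair in this set isolates that change. Among the measured compounds shown here, the only hint comes from compound 2, which also carries a substituent on the anilino ring and gives the higher number; the step from compound 1 to compound 3 in this assay is therefore expected to be modest, a 1.6-fold higher number from compound 1 to compound 3 (0.22 log units; within the scatter), toward a higher number or none beyond the scatter. Compound 3 is estimated at 6000 nM in this assay, with a range of 2500 nM to 15000 nM.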

Compound 3, concentration for 50% growth inhibition: 14800 nM
Beside the measured number, compound 3's estimate is 2.5-fold (0.39 log units) below it; the range from low to high includes it.
By their numbers in this assay, from the lowest: compound 1; then compounds 3 and 2 (each within the scatter of the next).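

In this assay, among these compounds, this is the first change at the anilino ring that can be read on its own: phenyl to 4-methoxyphenyl, with the rest of compound 1 unchanged, gives a clear move toward weaker inhibition of growth (a 4.1-fold higher number from compound 1 to compound 3 (0.61 log units; beyond the scatter)). The aromatic carbon para to a large group is therefore not indifferent to substitution, at least for methoxy in place of hydrogen on the core of compound 1. The earlier comparison of compound 1 with compound 2 spanned two places at once and could not show this. Nothing at hand accounts for the size or direction of the step.

From the compounds shown here alone, whether this loss of growth inhibition is particular to methoxy or extends to other groups at the same carbon remains open; fluorine, a hydroxyl group, an amine or a carboxylic acid there, on the core of compound 1, would test this. Going by these compounds, it is also open whether methoxy gives a similar step at other positions of the anilino ring, or on a core that differs elsewhere from that of compound 1.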